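The source may report more compounds than this note shows. Statements on the series, on what has been measured and on what is new or still open speak of the compounds shown alone.

Working notes on the series. Compound 1 `CN(C(=O)NC(=O)c1ccc(F)c(F)c1)c1nc(C(F)(F)F)c(C(=O)N/N=C/c2ccc(C(F)(F)F)cc2)s1`, compound 2 `CN(C(=O)NC(=O)c1ccc(C(F)(F)F)cc1)c1nc(C(F)(F)F)c(C(=O)N/N=C/c2ccc(C(F)(F)F)cc2)s1` and compound 3 `CN(C(=O)NC(=O)c1ccc(C(F)(F)F)cc1)c1nc(C(F)(F)F)c(C(=O)N/N=C/c2cccc(C(F)(F)F)c2)s1` have been measured in a functional assay on A549 cells (Homo sapiens) for inhibition, read by MTT assay, with a stated time of 72 h; on this read-out lower numbers stand for stronger inhibition and higher numbers for weaker inhibition; compound 4 `CN(C(=O)NC(=O)c1ccc(F)c(F)c1)c1nc(C(F)(F)F)c(C(=O)N/N=C/c2cccc(C(F)(F)F)c2)s1` has not. In this assay compound 1 gives 6.07 ug/mL and compound 3 gives 6.66 ug/mL, the two within the usual scatter of each other. For compound 2 the result in this assay is a limit of the assay, > 100 ug/mL, as recorded at the limit of > 100 ug/mL in this assay, at which 1 of the 3 values shown sits. The change 3,4-difluorophenyl in place of 4-(trifluoromethyl)phenyl on a carbonyl carbon brought an at least 16-fold lower number from compound 2 to compound 1 (1.21 log units; beyond the scatter). The cores of compound 2 and compound 3 differ by 3-(trifluoromethyl)phenyl in place of 4-(trifluoromethyl)phenyl on a carbon with a double bond to nitrogen, which brought an at least 15-fold lower number from compound 2 to compound 3 (1.17 log units; beyond the scatter). The same change as the first one, (3,4-difluorophenyl in place of 4-(trifluoromethyl)phenyl on a carbonyl carbon), is now made on compound 3, so compound 4 combines both alterations. Because compound 3 already stands at 6.66 ug/mL and because compound 1 stands at 6.07 ug/mL, the earlier step cannot be assumed to repeat at its full size from this starting point; the step from compound 3 to compound 4 is estimated as a 1.7-fold lower number from compound 3 to compound 4 (0.22 log units; within the scatter). Compound 4 is expected near 4 ug/mL, most likely between 1.5 ug/mL and 12 ug/mL.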

Compound 4, half-maximal inhibitory concentration: 6.52 ug/mL
For compound 4 the middle estimate is 1.6-fold (0.21 log units) below the measured one; low and high end bracket the measured number.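

In this assay the change to 3,4-difluorophenyl in place of 4-(trifluoromethyl)phenyl on a carbonyl carbon gave a 1.0-fold lower number from compound 3 to compound 4 (0.01 log units; within the scatter), so the large step seen on the core of compound 2 did not carry over to the core of compound 3: the same change on two cores in this assay, an at least 16-fold lower number (1.21 log units; beyond the scatter) from compound 2 to compound 1 and a 1.0-fold lower number (0.01 log units; within the scatter) from compound 3 to compound 4, at least 16-fold (1.20 log units) apart, beyond the scatter of two such steps

The change to 3-(trifluoromethyl)phenyl in place of 4-(trifluoromethyl)phenyl on a carbon with a double bond to nitrogen likewise gave a 1.1-fold higher number from compound 1 to compound 4 (0.03 log units; within the scatter), and it too did not repeat its earlier step: the same change on two cores in this assay, an at least 15-fold lower number (1.17 log units; beyond the scatter) from compound 2 to compound 3 and a 1.1-fold higher number (0.03 log units; within the scatter) from compound 1 to compound 4, at least 16-fold (1.20 log units) apart, beyond the scatter of two such steps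

Compound 2 gives > 100 ug/mL, which is a limit of the assay and not a number, and these four compounds do not show why neither change carried over or how either would behave on a further core.

Open, on these data alone, is whether a nitrile or a methoxy group on the phenyl at the carbonyl carbon would give a number different from those of compound 1, compound 3 and compound 4, which lie within the scatter of one another. Also open, as far as these compounds go, is whether an amine or a carboxylic acid on the other phenyl would do so.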